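A few compounds are considered here, and "the series" means these few. Any claim that something is new, unique, unknown or untested is made for them only; others in the source may bear on it.

Working notes on the series. In an assay on a protein complex for inhibition of CDK8/Cyclin C (Homo sapiens), with a stated time of 1 h, tested at 10 uM (a higher number here means more inhibition at the concentration tested (going by the name of the read-out), a lower number less inhibition), compound 1 `CNC(=O)/C=C/c1ccncc1-c1ccc2ccccc2c1` gives 101%. In this assay compound 2 `NNC(=O)CCc1ccncc1-c1ccc2ccccc2c1` gives 102%, and compound 3 `COC1CN(C(=O)/C=C/c2ccncc2-c2ccc3ccccc3c2)C1` gives 100% in this assay. Compound 3 holds the lowest of the three numbers, but it sits within the scatter of both others, so no order among them can be read. The step from compound 3 to compound 4 `O=C(/C=C/c1ccncc1-c1ccc2ccccc2c1)NC1CC1` is cyclopropylamino in place of 3-methoxyazetidin-1-yl on a carbonyl carbon. The step that bears on it most is the earlier change at the same carbonyl carbon, a number 1 percentage points lower from compound 1 to compound 3 (within the scatter); the other measured step, a number 1 percentage points higher from compound 1 to compound 2 (within the scatter), also stayed flat. A change at the amide nitrogen is therefore expected to leave this assay unmoved beyond the scatter, no change at the digits printed from compound 3 to compound 4 (within the scatter). Compound 4 is estimated at 100%, in the range 92% to 105%.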

Compound 4, a percentage reported as inhibition, at one concentration (the size of the read-out at that concentration, not a potency): 102%
For compound 4 the middle estimate is 2 percentage points below the measured one, within the range that was stated.
By their numbers in this assay, from the lowest: compounds 3, 1, 2 and 4 (each within the scatter of the next).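

At this carbonyl carbon, the 3-methoxyazetidin-1-yl group with no hydrogen-bond donor and the cyclopropylamino group with one read alike in this assay (a number 2 percentage points higher from compound 3 to compound 4 (within the scatter)). On the amide-type nitrogen, cyclopropyl is likewise not told apart from methyl (a number 1 percentage points higher from compound 1 to compound 4 (within the scatter)), and the saturated aminocarbamoyl side chain of compound 2 is not told apart from the 2-(cyclopropylcarbamoyl)ethenyl chain (no change at the digits printed from compound 2 to compound 4 (within the scatter)). No measurement offers an explanation for this flatness.

Still open, from the compounds shown here alone, is whether a carboxylic acid or a longer alkyl chain on the amide would move the number at all. With every value this close at a single concentration, differences among these amides remain unresolved.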